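The source may report more compounds than this note shows. Statements on the series, on what has been measured and on what is new or still open speak of the compounds shown alone.

Measured compounds:
Compound 1 `O=C(CC1CCCCC1)N1CCN(c2nc(=O)c3cc(C(F)(F)F)cc([N+](=O)[O-])c3s2)CC1`: > 125000 nM (a limit of the assay)
Compound 2 `O=c1nc(N2CCN(CC3CCCCC3)CC2)sc2c([N+](=O)[O-])cc(C(F)(F)F)cc12`: > 125000 nM (a limit of the assay)
Compound 3 `O=C(C1CCCCC1)N1CCN(c2nc(=O)c3cc(C(F)(F)F)cc([N+](=O)[O-])c3s2)CC1`: 88700 nM

These results come from an ADME assay on Vero cells (Chlorocebus sabaeus) for cytotoxicity, read by MTT assay, with a stated time of 72 h; a higher number here means that more compound is tolerated, a lower number that less compound is tolerated. Within the data shown here, compound 3 gives 88700 nM, the only true number among the three. The result for compound 1 is a limit, not a number. The result for compound 2 is likewise a limit, so compound 3 cannot be ranked exactly against either.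

Compound 4 `CC(C)CC(=O)N1CCN(c2nc(=O)c3cc(C(F)(F)F)cc([N+](=O)[O-])c3s2)CC1` differs from compound 3 in a single place: isobutyl in place of cyclohexyl on a carbonyl carbon. It carries isobutyl in place of cyclohexyl on a carbonyl carbon. Among the measured compounds shown here, no measured step makes this exact exchange. The nearest is an at least 1.4-fold lower number from compound 1 to compound 3 (0.14 log units; that floor lies within the scatter), which also changes the group on that carbonyl carbon, and its floor does not go beyond the scatter. The step of an at least 1.4-fold lower number from compound 2 to compound 3 (0.14 log units; that floor lies within the scatter) is of the same readable size, but it alters the link to the amine nitrogen in a ring. The step that the two limits leave unreadable from compound 1 to compound 2 offers no measure of size.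

In this assay, these steps give no ground for expecting a large shift, only perhaps a slightly higher number. The expected step is a 1.2-fold higher number from compound 3 to compound 4 (0.07 log units; within the scatter), which would stay within the scatter. For compound 4 the estimate is 105000 nM, with an expected range of 60000 nM to 165000 nM.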

Compound 4, half-maximal cytotoxic concentration: > 125000 nM
Compound 4 ended at the assay's limit; the forecaster's own chance of this, stated with the estimate: 40%; middle value at least 1.1-fold (0.07 log units) away from the limit.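

In this assay, compound 4 carries isobutyl in place of cyclohexyl on a carbonyl carbon, and its result, > 125000 nM, is a limit of the assay. Among these compounds, the exchange gives an at least 1.4-fold higher number from compound 3 to compound 4 (0.14 log units; that floor lies within the scatter), so it shows that an open chain without a ring can stand on this carbonyl carbon, whereas the earlier compounds with a group there, compound 1 and compound 3, both carry a cyclohexyl ring, but it does not establish a real change from compound 3. The steps that link compound 4 to compound 1 and to compound 2 cannot be read, and most of this small set now rests on one ceiling rather than on numbers: the limit of > 125000 nM in this assay, at which 3 of the 4 values shown sit.

The compounds shown leave open how far compound 4 truly lies from compound 3, and whether any group on this carbonyl carbon can give a step in this assay that goes beyond the scatter. They also leave open what a much shorter chain such as methyl, or a group carrying an amine or a carboxylic acid, would do at this place.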